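This account rests on a few compounds, and the source may have more. Where it says the series, first, only, none or still open, it means among the compounds named here.

Compound 1, `CC1=C(C(=O)Nc2ccc(F)cc2)C(c2ccc([N+](=O)[O-])cc2)N=C(SCc2ccccc2)N1`, gives 12.3% in a functional assay on the whole organism (artery, strain albino) with Rattus norvegicus as the target, with a stated time of 60 min, at a dose of 10 mg/kg by the oral route; on this read-out higher numbers stand for more inhibition at the one dose given (going by the name of the read-out) and lower numbers for less inhibition.
Compound 2, `CC1=C(C(=O)Nc2ccc(F)cc2)C(c2ccc([N+](=O)[O-])cc2)N=C(SCc2ccc(Cl)cc2)N1`, gives 11.8% in this assay.
Compound 3, `CC1=C(C(=O)Nc2ccc([N+](=O)[O-])cc2)C(c2ccc(Br)cc2)N=C(SCc2ccccc2Cl)N1`, gives 6.7% in this assay.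

Compound 3 has the lowest of these three numbers, yet its gaps to compound 2 and to compound 1 are both within the scatter, so the three cannot be ranked. Compound 4, `CC1=C(C(=O)Nc2ccc([N+](=O)[O-])cc2)C(c2ccc(Br)cc2)N=C(SCc2ccc(F)cc2)N1`, differs from compound 3 in one place: 4-fluorophenyl in place of 2-chlorophenyl on a saturated chain carbon bound to a sulfur. Among the compounds with values here, the one measured step that resembles it, a change of a substituent on the same kind of ring, is a number 0.5 percentage points lower from compound 1 to compound 2 (within the scatter), within the scatter. On that basis a step of a number 1.3 percentage points higher from compound 3 to compound 4 (within the scatter) is expected, no more than the scatter. Compound 4 is therefore estimated at 8%, between 0% and 20%.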

Compound 4, a percentage reported as inhibition, in the whole organism at one dose (the size of the read-out at that dose, not a potency): 9.7%
Estimate against measurement, compound 4: 1.7 percentage points below; low and high end bracket the measured number.
By their numbers in this assay, from the lowest: compounds 3, 4, 2 and 1 (each within the scatter of the next).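

The step from 2-chlorophenyl to 4-fluorophenyl on a saturated chain carbon bound to a sulfur reads a number 3 percentage points higher from compound 3 to compound 4 (within the scatter) in this assay. The earlier step only added a chloro, whereas this one replaces the halogen and changes where it sits on the ring, on the core of compound 3, and still does not leave the scatter. No measurement here offers an explanation for this result.

Every ring at this position carries only hydrogen or a halogen. Going by these compounds, whether an amine, a carboxylic acid or a longer chain in place of the benzyl group would separate from these compounds remains open.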